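The compounds below may be only part of what the source reports. "The series", "measured", "known", "first", "only" and "open" are said of these compounds alone.

Measured in a functional assay on RT-112 cells (Homo sapiens) for antiproliferative activity, read by MTT assay, with a stated time of 72 h; on this read-out higher numbers stand for weaker inhibition of growth and lower numbers for stronger inhibition of growth:
- compound 1 `COc1cc(Nc2ncnc3c(NC(=O)Nc4cccc(Cl)c4Cl)cccc23)cc(OC)c1`: 63.2 nM
- compound 2 `COc1cc(Nc2ncnc3c(NC(=O)Nc4ccc(F)cc4C(F)(F)F)cccc23)cc(OC)c1`: 2970 nM
- compound 3 `COc1cc(Nc2ncnc3c(NC(=O)Nc4ccc5c(c4)OCCO5)cccc23)cc(OC)c1`: 2750 nM

The upper pair of numbers is not separated (a 1.1-fold lower number from compound 2 to compound 3 (0.03 log units; within the scatter)) and the remaining entry lies far under it (a 44-fold higher number from compound 1 to compound 3 (1.64 log units; beyond the scatter)). Compound 3 therefore stands in the upper pair, at the weak end of growth inhibition in this small set.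

Compound 4 `COc1cc(Nc2ncnc3c(NC(=O)Nc4ccc(F)cc4F)cccc23)cc(OC)c1` carries 2,4-difluorophenyl in place of 2,3-dihydro-1,4-benzodioxin-6-yl on an amide-type nitrogen. For the measured compounds named here, no measured step makes this exact exchange. Halogen on the group does not settle the outcome: compound 1 with 2,3-dichlorophenyl gives 63.2 nM and compound 2 with 4-fluoro-2-(trifluoromethyl)phenyl gives 2970 nM in the same read-out. The large size of that gap (a 47-fold higher number from compound 1 to compound 2 (1.67 log units; beyond the scatter)) shows how far one exchange at this nitrogen can move the number, so the range must stay wide. The entering group shares fluorine with the group of compound 2, which argues against a large drop. In this assay the estimated step is a 2.1-fold lower number from compound 3 to compound 4 (0.33 log units; beyond the scatter) and is expected to be modest, toward stronger inhibition.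

The estimated value for compound 4 is 1300 nM (300 nM to 4000 nM).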

Compound 4, concentration for 50% growth inhibition: 2460 nM
Estimate against measurement, compound 4: 1.9-fold (0.28 log units) below; the range from low to high includes it.
By their numbers in this assay, from the lowest: compound 1; then compounds 4, 3 and 2 (each within the scatter of the next).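

In this assay, 2,4-difluorophenyl on the amide-type nitrogen gives a value not separated from those of the benzodioxinyl and trifluoromethyl-bearing analogues (a 1.1-fold lower number from compound 3 to compound 4 (0.05 log units; within the scatter); a 1.2-fold lower number from compound 2 to compound 4 (0.08 log units; within the scatter)), so three quite different groups now form one cluster. Compound 1 remains the strongest of the four, and the exchange of its 2,3-dichlorophenyl group for 2,4-difluorophenyl carries a large penalty (a 39-fold higher number from compound 1 to compound 4 (1.59 log units; beyond the scatter)), which makes compound 1 the lone exception at this position, while compound 2 and compound 4 show that fluorine on the ring does not by itself reproduce its value. The data at hand offer no measurement that explains why compound 1 separates from the other three.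

From the compounds shown here alone, what stays open is whether the value of compound 1 follows from chlorine as the halogen or from the 2,3-arrangement of its substituents: 2,4-dichlorophenyl and 2,3-difluorophenyl would separate these two readings. Going by these compounds, it is also open whether a non-halogen pair such as that in 2,3-dimethylphenyl, or a single chlorine as in 3-chlorophenyl, would fall with compound 1 or with the cluster.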